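Sulfanyl in Place of Hydrogen in a Cytotoxicity Series

The compounds below may be only part of what the source reports. "The series", "measured", "known", "first", "only" and "open" are said of these compounds alone.

Measured so far:
- compound 1, `CC1N=C(S)N(Nc2cccc(Cl)c2)C1C`, gives 259000 nM in a functional assay on MT4 cells (Homo sapiens) for cytotoxicity; a higher number here means that more compound is tolerated, a lower number that less compound is tolerated
- compound 2, `COC(=O)C1C(C)N=CN1Nc1cccc(Cl)c1`, gives 107000 nM in this assay

Compound 2 holds the lowest of the two numbers in this assay; the nearest is compound 1, whose higher number lies beyond the usual scatter. Compound 3, `COC(=O)C1C(C)N=C(S)N1Nc1cccc(Cl)c1`, differs from compound 2 by sulfanyl in place of hydrogen on a carbon with a double bond to nitrogen. Among the compounds with values here, no step between measured compounds is known; compound 1 also carries a sulfanyl group but differs from compound 2 in more than one place, so only its value can be noted. An upward step of moderate size is expected for a 1.7-fold higher number from compound 2 to compound 3 (0.23 log units; within the scatter). Compound 3 is therefore estimated at 180000 nM, with a range from 80000 nM to 400000 nM.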

Compound 3, half-maximal cytotoxic concentration: 190000 nM
Compound 3: the middle estimate sits 1.1-fold (0.02 log units) below what was measured, and the stated range covers the measured number.
By their numbers in this assay, from the lowest: compounds 2, 3 and 1 (each within the scatter of the next, the first and the last beyond it).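

In this assay, sulfanyl in place of hydrogen on the carbon with a double bond to nitrogen gives a 1.8-fold higher number from compound 2 to compound 3 (0.25 log units; within the scatter) and so does not separate this pair beyond the scatter. Methoxycarbonyl in place of methyl on a saturated ring carbon gives a 1.4-fold lower number from compound 1 to compound 3 (0.13 log units; within the scatter) and likewise stays within the scatter. No measurement at hand accounts for either step.

On these data alone, whether an amine or a longer chain on this carbon would move the number beyond the scatter remains open. Also open, as far as these compounds go, is whether the sulfanyl step holds on any core other than that of compound 2.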